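Cyano in place of acetyl on compound 2

A few compounds are considered here, and "the series" means these few. Any claim that something is new, unique, unknown or untested is made for them only; others in the source may bear on it.

In an ADME assay on TZM cells (Homo sapiens) for cytotoxicity, read by XTT assay, with a stated time of 4 days (a higher number here means that more compound is tolerated, a lower number that less compound is tolerated), three compounds of the series have been read, and none gives a number. Compound 1 (`Cc1cc(/C=C/C#N)cc(C)c1Oc1cc(Nc2ccc(C#N)cc2)c(N)cc1C(N)=O`) gives > 23600 nM as a limit of the assay. Compound 3 (`Cc1cc(CCC#N)cc(C)c1Oc1cc(Nc2ccc(C#N)cc2)c(N)cc1C(=O)NN`) gives > 22700 nM as a limit as well. Compound 2 (`CC(=O)/C=C/c1cc(C)c(Oc2cc(Nc3ccc(C#N)cc3)c(N)cc2C(F)(F)F)c(C)c1`) gives > 8600 nM as a limit too. Compound 2 therefore stands only as a limit, like the other two, and no order among the three can be read from them.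

Compound 4 (`Cc1cc(/C=C/C#N)cc(C)c1Oc1cc(Nc2ccc(C#N)cc2)c(N)cc1C(F)(F)F`) departs from compound 2 by one change (cyano in place of acetyl on a double-bonded chain carbon bound to a double-bonded chain carbon) which is cyano in place of acetyl on a double-bonded chain carbon bound to a double-bonded chain carbon, or 2-acetylethenyl to 2-cyanoethenyl.

For the measured compounds named here, no measured pair differs in one place only, so no measured step can be carried over. Compound 1 also carries the 2-cyanoethenyl group and gives > 23600 nM as a limit. The expected step is a step that the limit leaves unreadable from compound 2 to compound 4 in this assay and is not expected to go beyond the scatter in either direction. For compound 4 the estimated half-maximal cytotoxic concentration is 12000 nM with an expected range of 4000 nM to 23000 nM and a limit of the assay instead of a number is also expected to be possible.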

Compound 4, half-maximal cytotoxic concentration: 15000 nM
The estimate for compound 4 lay 1.3-fold (0.10 log units) below the measured number; the measured number falls inside the stated range.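

In this assay, for the compounds shown here, compound 4 gives 15000 nM, the first number rather than a limit, so 2-cyanoethenyl together with trifluoromethyl on the shared core reads inside the range of the assay. With 2-cyanoethenyl kept, trifluoromethyl in place of carbamoyl on an aromatic carbon gives an at least 1.5-fold lower number from compound 1 to compound 4 (0.19 log units; that floor lies within the scatter), so this change is not shown to go beyond the scatter, and its full size stays unknown because compound 1 rests on a limit: the limit of > 23600 nM in this assay, at which 1 of the 4 values shown sits.
The step for cyano in place of acetyl cannot be read in size or direction because compound 2 also rests on a limit: the limit of > 8600 nM in this assay, at which 1 of the 4 values shown sits.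

Still open, on these data alone, is whether a carboxylic acid or an amine in place of trifluoromethyl on that aromatic carbon would keep the read-out inside the range of this assay or return it to a limit. Also open, as far as these compounds go, is how a longer chain bearing the nitrile would read against 2-cyanoethenyl with everything else on the core held the same.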